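The source may report more compounds than this note shows. Statements on the series, on what has been measured and on what is new or still open speak of the compounds shown alone.

Measured so far in a functional assay on MCF7 cells (Homo sapiens) for inhibition, read by sulforhodamine B assay; on this read-out lower numbers stand for stronger inhibition and higher numbers for weaker inhibition:
compound 1 `O=C1C=C(NC2CCCC2)C(=O)c2c1nc1n2[C@H]2OC[C@@H](O)[C@H]2OC1`: > 16000 nM (a limit)
compound 2 `Cc1ccc(NC2=CC(=O)c3nc4n(c3C2=O)[C@H]2OC[C@@H](O)[C@H]2OC4)cc1`: 1660 nM

Among the measured compounds shown here, compound 2 holds the only actual number in this assay so far, 1660 nM. Compound 1 stands at a limit and not at a number: the limit of > 16000 nM in this assay, at which 1 of the 2 values shown sits.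

Compound 3 `O=C1C=C(Nc2cccc(Cl)c2)C(=O)c2c1nc1n2[C@H]2OC[C@@H](O)[C@H]2OC1` is the next case: 3-chlorophenyl in place of 4-methylphenyl on an amine nitrogen. In short, it has 3-chlorophenyl in place of 4-methylphenyl on an amine nitrogen.

For the measured compounds named here, one measured step bears on this, an at least 9.6-fold lower number from compound 1 to compound 2 (0.98 log units; beyond the scatter), which put 4-methylphenyl in place of cyclopentyl on that amine nitrogen. Going by the values given here, compound 3 keeps the six-membered aromatic ring of carbon only that compound 2 gained in that step, so the size of that step is not expected to repeat. Among the compounds with values here, no measured step changes a group on this ring, so the direction is poorly defined, and no shift beyond the scatter is expected in this assay. The expected change is a 1.2-fold lower number from compound 2 to compound 3 (0.07 log units; within the scatter). For compound 3 the estimated value is 1400 nM. The expected range for compound 3 runs from 450 nM to 4500 nM.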

Compound 3, half-maximal inhibitory concentration: 4720 nM
Estimate against measurement, compound 3: 3.4-fold (0.53 log units) below; measured number outside the range, above it.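

In this assay, the aryl group on this amine nitrogen is not freely interchangeable: 3-chlorophenyl in place of 4-methylphenyl, with the same heavy-atom count and the same type of ring, gives a 2.8-fold higher number from compound 2 to compound 3 (0.45 log units; beyond the scatter). An aryl group in place of cyclopentyl now goes with a lower number in two cases, since 3-chlorophenyl gives an at least 3.3-fold lower number from compound 1 to compound 3 (0.53 log units; beyond the scatter), and neither compound shown goes against this. Compound 1 holds a limit and not a number, so the steps from it give only a bound on their size: the limit of > 16000 nM in this assay, at which 1 of the 3 values shown sits.

The step from compound 2 to compound 3 changes the substituent and its place on the ring together, so the compounds shown do not separate the effect of chlorine from that of its place; 4-chlorophenyl or 3-methylphenyl on the same nitrogen would pull the two apart. Also open, on these data alone, is how unsubstituted phenyl compares with these two aryl groups, and whether a methoxy group or a dimethylamino group on the ring would move the number further in either direction.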